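Moving an amino group onto a second benzylic scaffold

The source may hold more compounds than are shown below. What is called first, only, known or untested is meant among the compounds shown, and "the series" means these compounds.

Of the compounds shown here, three have been measured in a functional assay on OVCAR-8 cells (Homo sapiens) for cytotoxicity, read by sulforhodamine B assay, with a stated time of 48 h; a higher number here means a weaker inhibitor of growth, a lower number a stronger inhibitor of growth. Compound 1 `ClCc1ccc(Cn2cnc3c(Cl)ncnc32)cc1` gives 15100 nM. Compound 2 `Nc1nc(Cl)c2ncn(Cc3ccc(CCl)cc3)c2n1` differs from compound 1 by one change, (amino in place of hydrogen on an aromatic carbon). In this assay compound 2 gives 33100 nM. That change made a step of a 2.2-fold higher number from compound 1 to compound 2 (0.34 log units; beyond the scatter), so adding the amino group here left growth inhibition somewhat weaker. Compound 3 `ClCc1ccccc1Cn1cnc2c(Cl)ncnc21` is built from the same atoms as compound 1, joined differently; the difference between the two cores is not broken down here. In this assay compound 3 gives 5240 nM. Compound 3 has the lowest number of the three, and its gaps to compound 1 and compound 2 both lie beyond the usual scatter.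

Compound 4 `Nc1nc(Cl)c2ncn(Cc3ccccc3CCl)c2n1` has not yet been measured. It differs from compound 3 by amino in place of hydrogen on an aromatic carbon, which is the same change that carried compound 1 to compound 2. The place of the change is described in the same words for both pairs, so the change is taken to be the same. Within the data shown here, the step from compound 3 to compound 4 in this assay is therefore expected to resemble the earlier one, an estimated 2.2-fold higher number from compound 3 to compound 4 (0.34 log units; beyond the scatter), because the only comparable evidence is the step of a 2.2-fold higher number from compound 1 to compound 2 (0.34 log units; beyond the scatter). On that basis compound 4 is estimated to give 11500 nM, expected to lie between 5000 nM and 30000 nM.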

Compound 4, concentration for total growth inhibition: 19500 nM
Estimate against measurement, compound 4: 1.7-fold (0.23 log units) below; the measured number falls inside the stated range.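

In this assay, putting the amino group onto the core of compound 3 gave a step of a 3.7-fold higher number from compound 3 to compound 4 (0.57 log units; beyond the scatter), so growth inhibition became weaker, as it had on the core of compound 1. Set side by side, the two steps point the same way and cannot be told apart in size: the same change on two cores in this assay, a 2.2-fold higher number (0.34 log units; beyond the scatter) from compound 1 to compound 2 and a 3.7-fold higher number (0.57 log units; beyond the scatter) from compound 3 to compound 4, 1.7-fold (0.23 log units) apart, within the scatter of two such steps. Within this small set, the change therefore carries over from one core to the other, but two pairs cannot show that it would do the same on a further core, nor do they explain why growth inhibition weakens.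

The compounds shown leave open whether a different group on the same aromatic carbon between two ring nitrogen atoms, such as a methyl, a hydroxyl or a methylamino group, would also weaken growth inhibition or would instead strengthen it. They also leave open how the amino step would change if the chloromethyl group on the benzyl ring gave way to another group, such as a hydroxymethyl group or a longer chloroalkyl chain.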